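This account rests on a few compounds, and the source may have more. Where it says the series, first, only, none or still open, it means among the compounds named here.

Working notes on the series.

Compound 1 `COc1cc(-c2cc(/C=C/C(=O)c3ccc(N)cc3)[nH]n2)cc(OC)c1OC` is the reference point. In a functional assay on SK-MEL-2 cells (Homo sapiens) for inhibition, read by sulforhodamine B assay, with a stated time of 48 h (on this read-out lower numbers stand for higher toxicity in this test and higher numbers for lower toxicity in this test), compound 1 gives 31900 nM. Compound 2 `COc1ccc(-c2cc(/C=C/C(=O)c3ccc(N)cc3)[nH]n2)cc1OC` differs from it in the shared core's aryl ring, and in this assay compound 2 gives 53200 nM. Within the data shown here, the one step taken so far is a 1.7-fold higher number from compound 1 to compound 2 (0.22 log units; within the scatter), so the two numbers stand within the usual scatter of each other and no order between compound 1 and compound 2 can be read from them.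

Compound 3 `COc1ccc(C(=O)/C=C/c2cc(-c3cc(OC)c(OC)c(OC)c3)n[nH]2)cc1` has not yet been measured in this assay. Relative to compound 1 the change is methoxy in place of amino on an aromatic carbon. Among the measured compounds shown here, the measured step from compound 1 to compound 2 concerns a different place and a different group, so it bears on this change only loosely; no measured pair shows methoxy in place of amino on an aromatic carbon of the shared core, and the step from compound 1 to compound 2 itself was within the scatter.

On that basis the expectation for compound 3 is a number close to that of compound 1, with a 1.1-fold higher number from compound 1 to compound 3 (0.04 log units; within the scatter) as the estimated step and a wide range allowed. Compound 3 is estimated at 35000 nM, between 12000 nM and 100000 nM.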

Compound 3, concentration lethal to 50% of the cells: 99200 nM
Estimate against measurement, compound 3: 2.8-fold (0.45 log units) below; the range from low to high includes it.
By their numbers in this assay, from the lowest: compounds 1, 2 and 3 (each within the scatter of the next, the first and the last beyond it).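

In this assay, among these compounds, going from 4-aminophenyl to 4-methoxyphenyl gives the first step that lies beyond the scatter, a 3.1-fold higher number from compound 1 to compound 3 (0.49 log units; beyond the scatter), so methoxy in place of amino at this position, on a six-membered aromatic ring of carbon only and para to a large group, goes with lower toxicity in this test. The earlier step, a 1.7-fold higher number from compound 1 to compound 2 (0.22 log units; within the scatter), lay within the scatter and concerned a different place, so it gave no readable order; this position is the first shown to move the number by a modest but readable amount. Nothing at hand accounts for this step.

The compounds shown leave open whether the higher number goes with the departure of amino or the arrival of methoxy, a question that a hydroxyl, a dimethylamino group or a longer ethoxy chain at the same position would help to separate. Going by these compounds, they also rest on a single pair built on the core of compound 1, so it remains open whether the same change gives a similar step with the other aryl pattern of compound 2.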